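Ester chain extensions and cytotoxicity on the shared core

The source may report more compounds than this note shows. Statements on the series, on what has been measured and on what is new or still open speak of the compounds shown alone.

Compound 1 `CC(=O)OCCc1c(-c2ccccc2Cl)c2cc(Cl)ccc2[nH]c1=O` carries the acetyl ester on the shared core. In an ADME assay on HepG2 2.2.15 cells (Homo sapiens) for cytotoxicity (on this read-out higher numbers stand for lower toxicity in this test and lower numbers for higher toxicity in this test), compound 1 gives 27000 nM, the lowest of the three numbers measured. Compound 2 `O=C(O)CCCC(=O)OCCc1c(-c2ccccc2Cl)c2cc(Cl)ccc2[nH]c1=O` gives 110000 nM and compound 3 `O=C(COc1ccccc1)OCCc1c(-c2ccccc2Cl)c2cc(Cl)ccc2[nH]c1=O` gives 81000 nM. Both enlargements of the acetyl group moved the number upward: a 4.1-fold higher number from compound 1 to compound 2 (0.61 log units; beyond the scatter) and a 3.0-fold higher number from compound 1 to compound 3 (0.48 log units; beyond the scatter), whereas between the two enlarged esters a 1.4-fold lower number from compound 2 to compound 3 (0.13 log units; within the scatter). Compound 4 `O=C(CCOc1ccccc1)OCCc1c(-c2ccccc2Cl)c2cc(Cl)ccc2[nH]c1=O` differs from compound 1 by phenoxymethyl in place of hydrogen on a saturated chain carbon bound to a carbonyl carbon. Among the measured compounds shown here, the step from compound 1 to compound 3 is the closest precedent, and the step to compound 2 points the same way, so a modest rise in this assay is expected: a 3.0-fold higher number from compound 1 to compound 4 (0.47 log units; beyond the scatter). Compound 4 is therefore estimated at 80000 nM, within a range from 35000 nM to 180000 nM.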

Compound 4, half-maximal cytotoxic concentration: 46000 nM
Compound 4: the middle estimate sits 1.7-fold (0.24 log units) above what was measured, and the stated range covers the measured number.
By their numbers in this assay, from the lowest: compounds 1, 4, 3 and 2 (each within the scatter of the next, the first and the last beyond it).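

Phenoxymethyl at this saturated chain carbon bound to a carbonyl carbon does not clearly separate the new ester from the acetyl ester (a 1.7-fold higher number from compound 1 to compound 4 (0.23 log units; within the scatter)), so enlarging the acetyl group does not always move the number beyond the scatter. The two phenoxy-bearing esters also stay unseparated (a 1.8-fold lower number from compound 3 to compound 4 (0.25 log units; within the scatter)), while the 2-carboxyethyl ester stands apart from the phenoxymethyl one (a 2.4-fold lower number from compound 2 to compound 4 (0.38 log units; beyond the scatter)). Nothing available explains these differences.

On these data alone, how an amine or a longer alkyl chain at this place would read remains open.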